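The compounds below may be only part of what the source reports. "The series", "measured", "known", "first", "only" and "open" are said of these compounds alone.

Three compounds share one core and differ only in the halogen-bearing phenyl group attached to the amide nitrogen. Compound 1 `O=C(CSc1nc(Nc2ccccc2)c2ccccc2n1)Nc1ccccc1Br` carries a 2-bromophenyl there, and in a functional assay on MGC-803 cells (Homo sapiens) for inhibition, read by MTT assay, with a stated time of 72 h (on this read-out higher numbers stand for weaker inhibition and lower numbers for stronger inhibition), compound 1 gives 18600 nM. Compound 2 `O=C(CSc1nc(Nc2ccccc2)c2ccccc2n1)Nc1cccc(F)c1` carries a 3-fluorophenyl, and in this assay compound 2 gives 12700 nM. Compound 3 `O=C(CSc1nc(Nc2ccccc2)c2ccccc2n1)Nc1cccc(Cl)c1` carries a 3-chlorophenyl, and in this assay compound 3 gives 14300 nM. Among the three numbers compound 3 stands second highest, yet its separation from both neighbours is small: a 1.1-fold higher number from compound 2 to compound 3 (0.05 log units; within the scatter), and a 1.3-fold lower number from compound 1 to compound 3 (0.11 log units; within the scatter).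

Compound 4 `O=C(CSc1nc(Nc2ccccc2)c2ccccc2n1)Nc1cccc(Br)c1` is reached from compound 3 by one change: bromo in place of chloro on an aromatic carbon. The step that speaks most directly to this is the earlier halogen swap at the same spot, a 1.1-fold higher number from compound 2 to compound 3 (0.05 log units; within the scatter), which stayed within the scatter. The two other steps, a 1.5-fold lower number from compound 1 to compound 2 (0.17 log units; within the scatter) and a 1.3-fold lower number from compound 1 to compound 3 (0.11 log units; within the scatter), also changed the halogen and its place without moving beyond the scatter. Trading chloro for bromo is therefore expected to give a 1.0-fold higher number from compound 3 to compound 4 (0.02 log units; within the scatter), with no step beyond the scatter in this assay. Compound 4 is estimated at 15000 nM, in a range from 7500 nM to 30000 nM.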

Compound 4, half-maximal inhibitory concentration: 9620 nM
The estimate for compound 4 lay 1.6-fold (0.19 log units) above the measured number; measured number inside the range.
By their numbers in this assay, from the lowest: compounds 4, 2, 3 and 1 (each within the scatter of the next).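

With bromo at this place, all three halogens have now been tried on the same carbon of the phenyl ring, and in this assay bromo in place of chloro gives a 1.5-fold lower number from compound 3 to compound 4 (0.17 log units; within the scatter), while bromo in place of fluoro gives a 1.3-fold lower number from compound 2 to compound 4 (0.12 log units; within the scatter). Fluoro, chloro and bromo can therefore be exchanged here without any step beyond the scatter, so this assay does not separate these three compounds by their halogen. Within the data shown here, compound 4 also forms the first pair with the same halogen at two different places, and 3-bromophenyl in place of 2-bromophenyl gives a 1.9-fold lower number from compound 1 to compound 4 (0.29 log units; within the scatter), the widest step so far but still within the scatter, while nothing measured here gives a reason for any of these steps.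

The compounds shown leave open whether a group of another kind at this place, such as a methoxy group, an amine or a carboxylic acid, would give a step beyond the scatter. They also leave open whether a longer chain leading to the amide carbonyl would do so.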